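This account rests on a few compounds, and the source may have more. Where it says the series, first, only, none or still open, it means among the compounds named here.

Series notes. Compound 1 `COc1ccc(CNc2nc([Se]C)nc3ccccc23)cc1` in a functional assay on HTB-54 cells (Homo sapiens) for cytotoxicity, read by MTT assay, with a stated time of 72 h (a lower number here means a stronger inhibitor of growth, a higher number a weaker inhibitor of growth), gives 33000 nM. Compound 2 `[SeH]c1nc(NCc2ccccc2)c2ccccc2n1` in this assay gives 31200 nM; the values of compound 2 and compound 1 lie within the usual scatter of each other, so no order between them is claimed. Compound 3 `C[Se]c1nc(NCc2ccccc2)c2ccccc2n1` differs from compound 2 by methyl in place of hydrogen on a selenium. For the measured compounds named here, no measured pair shows this change directly, though compound 1 also carries a methyl on its selenium and sits close to compound 2. The step from compound 2 to compound 3 in this assay is therefore expected to stay within the scatter: a 1.0-fold lower number from compound 2 to compound 3 (0.02 log units; within the scatter). Compound 3 is expected to give 30000 nM, in the range 12000 nM to 75000 nM.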

Compound 3, concentration for 50% growth inhibition: 74600 nM
Estimate against measurement, compound 3: 2.5-fold (0.40 log units) below; low and high end bracket the measured number.
By their numbers in this assay, from the lowest: compounds 2 and 1 (each within the scatter of the next); then compound 3.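

Methyl in place of hydrogen on a selenium now has a direct reading in this assay: a 2.4-fold higher number from compound 2 to compound 3 (0.38 log units; beyond the scatter) is modest, but it shows that this place responds to the change. With methyl on the selenium in both compounds, hydrogen in place of methoxy on an aromatic carbon gives a 2.3-fold higher number from compound 1 to compound 3 (0.35 log units; beyond the scatter), so that aromatic place also bears on the number. No measurement on hand accounts for either step.

From the compounds shown here alone, whether a longer chain such as ethyl on the selenium would continue the trend from hydrogen to methyl remains open. So does whether an amine or a carboxylic acid in place of methoxy would move the number as hydrogen does.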